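The source may hold more compounds than are shown below. What is called first, only, known or untested is meant among the compounds shown, and "the series" means these compounds.

Compound 1 `COc1ccc(-c2cc(/C=C/C(=O)c3ccc(N)cc3)[nH]n2)cc1` and compound 2 `COc1cc(-c2cc(/C=C/C(=O)c3ccc(Cl)c(Cl)c3)[nH]n2)cc(OC)c1OC` were both tested in a functional assay on SK-MEL-28 cells (Homo sapiens) for cytotoxicity, read by sulforhodamine B assay, with a stated time of 48 h, tested at 10 uM; a higher number here means a weaker effect of the compound at the concentration tested, a lower number a stronger effect. In this assay compound 1 gives -60%, and compound 2 gives 73%, the highest of the two numbers and beyond the scatter above compound 1. Compound 3 `COc1ccc(C(=O)/C=C/c2cc(-c3cc(OC)c(OC)c(OC)c3)n[nH]2)cc1` has not yet been measured; it differs from compound 2 by one change, (4-methoxyphenyl in place of 3,4-dichlorophenyl on a carbonyl carbon). Among the measured compounds shown here, with no measured step of this kind to lean on, the expected change in this assay is a fall of moderate size, beyond the scatter, a number 43 percentage points lower from compound 2 to compound 3 (beyond the scatter). For compound 3 the estimate in this assay is 30%, within a range from -30% to 80%.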

Compound 3, a percentage reported as activity, at one concentration (the size of the read-out at that concentration, not a potency): -55%
Compound 3: the middle estimate sits 85 percentage points above what was measured, and the stated range ends above it.
By their numbers in this assay, from the lowest: compounds 1 and 3 (each within the scatter of the next); then compound 2.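

On the carbonyl carbon, the choice of aromatic group matters greatly: in this assay, 4-methoxyphenyl in place of 3,4-dichlorophenyl gives a number 128 percentage points lower from compound 2 to compound 3 (beyond the scatter), a large move towards a stronger effect at the concentration tested. The two groups match in heavy-atom count and ring type, so the step comes with a change of substituents alone, chlorine leaving and oxygen entering. Nothing available explains the size of this step.

On these data alone, this is a single pair, so it remains open how a plain phenyl or a 4-chlorophenyl would read at this place on the same core. As far as these compounds go, whether the step would hold on a different core also remains open.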